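Extending the alkyl chain on the aryl ring

The compounds below may be only part of what the source reports. "The series", "measured", "known", "first", "only" and "open" are said of these compounds alone.

Compounds measured so far in a functional assay on M21 cells (Homo sapiens) for antiproliferative activity, read by sulforhodamine B assay, with a stated time of 48 h; on this read-out lower numbers stand for stronger inhibition of growth and higher numbers for weaker inhibition of growth:
compound 1, `CCCCc1ccc(-c2cc(N3CCC(CNS(N)(=O)=O)CC3)ncn2)cc1`: 47200 nM
compound 2, `NS(=O)(=O)NCCC1CCN(c2cc(-c3ccccc3)ncn2)CC1`: the assay returns only a limit, > 100000 nM
compound 3, `Cc1ccc(-c2cc(N3CCC(CCNS(N)(=O)=O)CC3)ncn2)cc1`: 57600 nM

Compound 3 gives the highest of the two numbers reported. Its nearest neighbour is compound 1, whose value differs from that of compound 3 by an amount within the usual scatter, so the two cannot be ordered. The reading for compound 2 is a limit of the assay and not a number (the limit of > 100000 nM in this assay, at which 1 of the 3 values shown sits).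

The next compound, compound 4, `CCCCc1ccc(-c2cc(N3CCC(CCNS(N)(=O)=O)CC3)ncn2)cc1`, differs from compound 3 by propyl in place of hydrogen on a saturated chain carbon bound to an aromatic carbon; cut one bond further out, the same difference reads methyl to butyl. Among the compounds with values here, only one measured step speaks to alkyl growth on this part of the molecule: an at least 1.7-fold lower number from compound 2 to compound 3 (0.23 log units; that floor lies within the scatter), with its floor lying within the scatter. The values of compound 1 and compound 3, which carry a butyl and a methyl group on different chain lengths to the sulfamide, also sit within the scatter of each other. On this evidence no change beyond the scatter is expected for the step from compound 3 to compound 4, and the estimated step is a 1.3-fold lower number from compound 3 to compound 4 (0.11 log units; within the scatter). Compound 4 is therefore estimated at 45000 nM in this assay, within a range of 20000 nM to 100000 nM.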

Compound 4, concentration for 50% growth inhibition: 15100 nM
Beside the measured number, compound 4's estimate is 3.0-fold (0.47 log units) above it, outside the stated range (below it).
By their numbers in this assay, from the lowest: compound 4; then compounds 1 and 3 (each within the scatter of the next). At a limit, above all of these: compound 2.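

In this assay, within the data shown here, the step of a 3.8-fold lower number from compound 3 to compound 4 (0.58 log units; beyond the scatter) is the first change of alkyl group on the aryl ring that clears the scatter, so growth from methyl to butyl at this place does lower the number, which the methyl step alone, an at least 1.7-fold lower number from compound 2 to compound 3 (0.23 log units; that floor lies within the scatter), could not establish. The step of a 3.1-fold lower number from compound 1 to compound 4 (0.49 log units; beyond the scatter) adds a second finding: with butyl held constant, the change from sulfamoylamino to (sulfamoylamino)methyl on a saturated chain carbon bound to a saturated ring carbon also goes beyond the scatter, which compounds 1 and 3, differing in two places, could not show. Set against the unsubstituted compound, butyl gives an at least 6.6-fold lower number from compound 2 to compound 4 (0.82 log units; beyond the scatter), but this is a floor only, as the reading for compound 2 is a limit and not a number: the limit of > 100000 nM in this assay, at which 1 of the 4 values shown sits.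

The compounds shown leave open whether the number falls steadily with chain length, since a propyl group or a longer chain such as hexyl on the aryl ring would be needed to tell a trend from a single step. They also leave open whether the sulfamide end could give way to an amine or a carboxylic acid.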